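Three side chains on one core, and a fourth to come

The source may report more compounds than this note shows. Statements on the series, on what has been measured and on what is new or still open speak of the compounds shown alone.

Three compounds have been measured in an assay for inhibition of RAC-alpha serine/threonine-protein kinase (Homo sapiens), read by HTRF, with a stated time of 1 h; a lower number here means a stronger inhibitor, a higher number a weaker inhibitor:

Compound 1, `CNC(=O)C[C@@H]1C[C@@H](c2ccc(Cl)c(Cl)c2)[C@H](NC(=O)c2cc(-c3c(Cl)cnn3C)c(Cl)o2)CN1`: 2.64 nM
Compound 2, `Cn1ncc(Cl)c1-c1cc(C(=O)N[C@@H]2CN[C@H](CCn3cncn3)C[C@H]2c2ccc(Cl)c(Cl)c2)oc1Cl`: 4.47 nM
Compound 3, `Cn1ncc(Cl)c1-c1cc(C(=O)N[C@@H]2CN[C@H](CC(N)=O)C[C@H]2c2ccc(Cl)c(Cl)c2)oc1Cl`: 3.24 nM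

Compound 3 gives the second highest of the three numbers, yet it sits within the scatter of both neighbours: the step of a 1.2-fold higher number from compound 1 to compound 3 (0.09 log units; within the scatter) and the step of a 1.4-fold lower number from compound 2 to compound 3 (0.14 log units; within the scatter) are each too small to count, as is the step of a 1.7-fold higher number from compound 1 to compound 2 (0.23 log units; within the scatter) between the other two. On these numbers no one of the three can be called the stronger inhibitor.

Compound 4, `CN(C)CC[C@@H]1C[C@@H](c2ccc(Cl)c(Cl)c2)[C@H](NC(=O)c2cc(-c3c(Cl)cnn3C)c(Cl)o2)CN1`, carries the same core and differs from compound 3 in one place: (dimethylamino)methyl in place of carbamoyl on a saturated chain carbon bound to a saturated ring carbon. Among the measured compounds shown here, the steps that bear on this change are those at the same position, from compound 1 to compound 3 and from compound 2 to compound 3, both within the scatter. Three different groups on that chain carbon have left this assay essentially unmoved, so a fourth is expected to do the same. Compound 4 is therefore estimated at 3.5 nM, with a range from 1.5 nM to 8 nM. This estimate means an expected step of a 1.1-fold higher number from compound 3 to compound 4 (0.03 log units; within the scatter), not beyond the scatter in either direction.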

Compound 4, half-maximal inhibitory concentration: 3.4 nM
Estimate against measurement, compound 4: 1.0-fold (0.01 log units) above; low and high end bracket the measured number.
By their numbers in this assay, from the lowest: compounds 1, 3, 4 and 2 (each within the scatter of the next).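

In this assay, (dimethylamino)methyl in place of carbamoyl on a saturated chain carbon bound to a saturated ring carbon gives the step of a 1.0-fold higher number from compound 3 to compound 4 (0.02 log units; within the scatter), and the comparisons with the other two side chains read the same way, with the step of a 1.3-fold higher number from compound 1 to compound 4 (0.11 log units; within the scatter) and the step of a 1.3-fold lower number from compound 2 to compound 4 (0.12 log units; within the scatter). What compound 4 adds is a different kind of group: the side chains of compound 1, compound 2 and compound 3 each hold a carbonyl or a ring, whereas (dimethylamino)methyl holds neither, and compared with carbamoyl it has no hydrogen-bond donor and no double bond outside aromatic rings. Among these four compounds, then, neither the carbonyl, the ring nor the donor is needed for a number in this range, and no compound shown goes against that reading.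

Nothing shown here accounts for this lack of separation among the side chains. Going by these compounds, whether the same holds for a carboxylic acid, a primary amine or a longer chain at this place stays open, as does the outcome of replacing the whole side chain with hydrogen.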